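The source may report more compounds than this note shows. Statements on the series, on what has been measured and on what is new or still open speak of the compounds shown alone.

Measured compounds:
Compound 1 `CC1(C)[C@H]2CC3=N[C@H](CCC(=O)O)C(=O)O[C@]3(C)[C@@H]1C2` gives 30000 nM in a functional assay on EL4 cells (Mus musculus) for antiproliferative activity, read by sulforhodamine B assay, with a stated time of 48 h; on this read-out lower numbers stand for stronger inhibition and higher numbers for weaker inhibition.
Compound 2 `CC(C)(C)OC(=O)CC[C@H]1N=C2C[C@H]3C[C@H](C3(C)C)[C@@]2(C)OC1=O` gives 51000 nM in this assay.
Compound 3 `CC(C)(C)OC(=O)NCCCC[C@H]1N=C2C[C@H]3C[C@H](C3(C)C)[C@@]2(C)OC1=O` gives 14500 nM in this assay.

Compound 2 has the highest number of the three. Its nearest neighbour is compound 1, and the step of a 1.7-fold higher number from compound 1 to compound 2 (0.23 log units; within the scatter) lies within the scatter, so the two cannot be told apart. Among the compounds with values here, compound 3 shows a lower number than compound 2, a gap beyond the scatter, but no single-point step connects these two compounds, and their values are all that can be said.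

Compound 4 `CC(C)(C)OC(=O)CC[C@@H]1N=C2C[C@@H]3C[C@@H](C3(C)C)[C@]2(C)OC1=O` differs from compound 2 as follows: the two compounds have the same atoms and bonds and differ only in configuration as drawn: 4 of 4 stereo elements differ (all stereocentres are inverted: mirror images); a stereocentre at a saturated ring carbon is drawn R in compound 2 and S in compound 4; a stereocentre at a saturated ring carbon is drawn R in compound 2 and S in compound 4; a stereocentre at a saturated ring carbon is drawn R in compound 2 and S in compound 4; a stereocentre at a saturated ring carbon is drawn R in compound 2 and S in compound 4. Within the data shown here, the only measured step concerns a tert-butyl group in place of hydrogen on an oxygen, not configuration, so no measured step bears on this change. Compound 4 is therefore estimated near compound 2, with a wide range: the expected value is 50000 nM, between 12000 nM and 150000 nM. The step of a 1.0-fold lower number from compound 2 to compound 4 (0.01 log units; within the scatter) expected from this estimate is essentially none, with its direction unknown.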

Compound 4, half-maximal inhibitory concentration: 36000 nM
Compound 4: middle estimate off by 1.4-fold (0.14 log units), on the high side; measured number inside the range.
By their numbers in this assay, from the lowest: compound 3; then compounds 1, 4 and 2 (each within the scatter of the next).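

Within the data shown here, until this pair, the only measured step concerned the tert-butyl group, so configuration had not been tested. In this assay, full inversion of the stereocentres comes with a 1.4-fold lower number from compound 2 to compound 4 (0.15 log units; within the scatter), so on this read-out the two mirror-image tert-butyl esters cannot be told apart. The comparison isolates configuration alone, with no other structural change involved: the fact that compounds 2 and 4 differ only in the configuration as drawn.

All the stereocentres changed together, so the compounds shown do not tell what inverting a single one would do, or whether mirror images of compound 1 or compound 3 would also stay this close. Also open, from the compounds shown here alone, is what a primary amine in place of the ester-bearing chain would give, set against compound 3 at 14500 nM.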